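Three analogues at the limit and a fourth to come

This account rests on a few compounds, and the source may have more. Where it says the series, first, only, none or still open, it means among the compounds named here.

Compound 1: `Cc1nc(C)c([C@H](OC(C)(C)C)C(=O)O)c(N2CCC(C)(C)CC2)c1-c1ccc(Cc2ccccc2)cc1`, >= 20000 nM
Compound 2: `Cc1nc(C)c([C@H](OC(C)(C)C)C(=O)O)c(N2CCC(C)(C)CC2)c1-c1ccc(OCCc2ccc(C#N)cc2)cc1`, >= 33500 nM
Compound 3: `Cc1nc(C)c([C@H](OC(C)(C)C)C(=O)O)c(N2CCC(C)(C)CC2)c1-c1ccc(OCCc2ccc(F)cc2F)cc1`, >= 33500 nM

Three compounds share one core and differ only in the group on the outer aromatic ring. In a toxicity assay on MT2 cells (Homo sapiens) for cytotoxicity, read by XTT assay, with a stated time of 4 days (a higher number here means that more compound is tolerated, a lower number that less compound is tolerated), compound 1 gives >= 20000 nM, which is a limit of the assay and not a number. In this assay compound 2 gives >= 33500 nM, again a limit. Compound 3 gives >= 33500 nM, also a limit. Compound 3 therefore stands only at a limit, as do the other two values shown. Among the compounds with values here, the steps a step that the two limits leave unreadable from compound 1 to compound 2, a step that the two limits leave unreadable from compound 1 to compound 3 and a step that the two limits leave unreadable from compound 2 to compound 3 all remain unreadable; the only evidence is the limit of >= 20000 nM in this assay, at which 1 of the 3 values shown sits, and (the limit of >= 33500 nM in this assay, at which 2 of the 3 values shown sit).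

Compound 4 is `Cc1nc(C)c([C@H](OC(C)(C)C)C(=O)O)c(N2CCC(C)(C)CC2)c1-c1ccc(OCCc2ccc(F)c(F)c2)cc1`. It differs from compound 3 by 3,4-difluorophenyl in place of 2,4-difluorophenyl on a saturated chain carbon, two bonds along the chain from an oxygen on an aromatic ring. The step from compound 2 to compound 3, which also swaps one such ring for another, bears on this change, and its size could not be read. No readable step therefore supports any expectation beyond the scatter, and compound 4 is expected to sit at a limit as well, an expected step of a number no higher from compound 3 to compound 4 (the limit leaves the size open). For compound 4 the estimated value is 33500 nM, with a range from 15000 nM to 60000 nM.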

Compound 4, half-maximal cytotoxic concentration: >= 33500 nM
Compound 4 was reported as a limit (the forecaster's own chance of this, stated with the estimate: 85%); the middle value lies on the limit itself.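

In this assay compound 4 gives >= 33500 nM, which is a limit and not a number, so its steps from compound 1, compound 2 and compound 3 cannot be read. The compounds shown leave open at what concentration any of the four turns cytotoxic.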